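Turning Two Double Bonds from Z to E

The source may hold more compounds than are shown below. What is called first, only, known or untested is meant among the compounds shown, and "the series" means these compounds.

Among the compounds with values here, in an ADME assay on NIH3T3 cells (Mus musculus) for cytotoxicity, read by WST assay, with a stated time of 72 h (a higher number here means that more compound is tolerated, a lower number that less compound is tolerated), compound 2 (`CCCCCCCC/C=C\c1c(C)c(/C=C\CCCCCCCC)c2[n+](c1C)CCC2`) gives 23.5 uM, the highest of the three numbers so far. Compound 1 (`CCCCCCCCCCc1c(C)c(CCCCCCCCCC)c2[n+](c1C)CCC2`) gives 5.1 uM and compound 3 (`CCCCCCCCCCc1c(C)c(CCCCCCCCCC)c2[n+](c1C)CCCC2`) gives 3.8 uM, both clearly lower than compound 2. Compound 4 (`CCCCCCCC/C=C/c1c(C)c(/C=C/CCCCCCCC)c2[n+](c1C)CCC2`) has the same atoms and bonds as compound 2 and differs only in configuration as drawn: the two compounds have the same atoms and bonds and differ only in configuration as drawn: 2 of 2 stereo elements differ; a double bond is drawn Z in compound 2 and E in compound 4; a double bond is drawn Z in compound 2 and E in compound 4. Within the data shown here, no measured pair shows this kind of change, so the size of the step is uncertain. A modest drop in this assay is expected, with compound 1 at 5.1 uM as a rough lower guide. The expected change is a 1.7-fold lower number from compound 2 to compound 4 (0.22 log units; within the scatter). For compound 4 the estimated value is 14 uM, within an expected range from 6 uM to 30 uM.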

Compound 4, half-maximal toxic concentration: 4.4 uM
Compound 4: middle estimate off by 3.2-fold (0.50 log units), on the high side; the whole stated range lies above it.
By their numbers in this assay, from the lowest: compounds 3, 4 and 1 (each within the scatter of the next); then compound 2.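

In this assay the drawn geometry of the two double bonds matters on its own: going from Z to E gives a 5.3-fold lower number from compound 2 to compound 4 (0.73 log units; beyond the scatter), so less compound is tolerated. The earlier compounds shown here held no pair that could isolate configuration, whereas this pair changes nothing else: the fact that compounds 2 and 4 differ only in the configuration as drawn.

As far as these compounds go, both double bonds change together here, so how much each one contributes stays open. From the compounds shown here alone, whether a longer chain would keep the same gap between the Z and E forms also remains unknown.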